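Cyclohexyl in place of cyclopent-1-en-1-yl: working notes

The source may report more compounds than this note shows. Statements on the series, on what has been measured and on what is new or still open speak of the compounds shown alone.

Of the compounds shown here, two have been measured so far. In a functional assay on MT2 cells (Homo sapiens) for cytotoxicity, read by MTT assay (on this read-out lower numbers stand for higher toxicity in this test and higher numbers for lower toxicity in this test), compound 1 (`CC/C(C)=C\COc1cc(Nc2nccs2)ccc1Cl`) gives 18000 nM, and compound 2 (`Clc1ccc(Nc2nccs2)cc1OCC1=CCCC1`) gives 15000 nM. Compound 2 therefore stands within the scatter of compound 1, and neither can be ranked on these numbers.

The next compound is compound 3 (`Clc1ccc(Nc2nccs2)cc1OCC1CCCCC1`), with cyclohexyl in place of cyclopent-1-en-1-yl on a saturated chain carbon bound to an oxygen on an aromatic ring. The same change reads as (cyclopent-1-en-1-yl)methyl to cyclohexylmethyl.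

Among the measured compounds shown here, one measured step bears on this change, at the same place: a 1.2-fold lower number from compound 1 to compound 2 (0.08 log units; within the scatter). That step lies within the scatter. For the measured compounds named here, no measured compound carries cyclohexyl, so the evidence is thin and the range is kept wide. With that single step as the guide, no shift beyond the scatter is expected in this assay, in either direction. The expected step is no change at the digits printed from compound 2 to compound 3 (within the scatter).

For compound 3 the estimated value is 15000 nM, with an expected range from 7000 nM to 32000 nM.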

Compound 3, half-maximal cytotoxic concentration: 15000 nM
Compound 3: middle estimate and measured number agree at the digits printed, within the range that was stated.
By their numbers in this assay, from the lowest: compounds 2, 3 and 1 (each within the scatter of the next).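

In this assay, replacing the five-membered ring that carries a double bond with the six-membered ring that has none gives (no change at the digits printed from compound 2 to compound 3 (within the scatter)), so at this place, on a saturated chain carbon bound to an oxygen on an aromatic ring, a group without a double bond outside aromatic rings reads the same as one with it. Cyclohexyl and the open-chain 2-methylbut-1-en-1-yl group also cannot be told apart (a 1.2-fold lower number from compound 1 to compound 3 (0.08 log units; within the scatter)), which means that all three carbon-only groups in compounds 1, 2 and 3, whether open-chain or ring, now fall within the scatter of one another. No supporting data are at hand that could account for this flat reading.

The step from compound 2 to compound 3 alters ring size and the double bond together, and a cyclopentyl group at the same place would be needed to separate the two. On these data alone, whether a group carrying an amine or a carboxylic acid at this place would shift the number beyond the scatter remains open, since every group compared so far contains carbon only.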